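One Double Bond, Drawn Two Ways

The compounds below may be only part of what the source reports. "The series", "measured", "known", "first", "only" and "open" are said of these compounds alone.

In a functional assay on K562 cells (Homo sapiens) for inhibition, read by trypan blue exclusion, with a stated time of 48 h (a lower number here means a stronger inhibitor, a higher number a weaker inhibitor), compound 1 `O=C(CCCCCCNC(=O)c1ccc(-c2ccc(-c3cc(O)cc(O)c3)cc2)cc1)NO` gives 2500 nM while compound 2 `COc1cc(/C=C/c2ccc(OC)c(NC(=O)CCCCCCC(=O)NO)c2)cc(OC)c1` gives 700 nM as the lower of the two numbers. The gap between them goes beyond the scatter of repeated measurements, so compound 2 is the stronger inhibitor of this pair. The two structures differ in more than one place, however, so the gap cannot be tied to any single feature.

The change to compound 3 `COc1cc(/C=C\c2ccc(OC)c(NC(=O)CCCCCCC(=O)NO)c2)cc(OC)c1` is far smaller: the two compounds have the same atoms and bonds and differ only in configuration as drawn: 1 of 1 stereo elements differ; a double bond is drawn E in compound 2 and Z in compound 3 and nothing else. The two compounds have the same atoms and bonds, but a double bond is drawn E in compound 2 and Z in compound 3. Going by the values given here, no measured pair here shows what such a switch does, so neither direction can be favoured with confidence. A small change that stays within the scatter is the cautious expectation, although a larger shift either way remains possible. The estimated step is a 1.2-fold lower number from compound 2 to compound 3 (0.07 log units; within the scatter) and it is only a working guess. In this assay compound 3 is estimated at 600 nM with an expected range from 150 nM to 2400 nM and that width reflects how little is known so far.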

Compound 3, half-maximal inhibitory concentration: 7500 nM
Compound 3: middle estimate off by 13-fold (1.10 log units), on the low side, and the stated range ends below it.
By their numbers in this assay, from the lowest: compound 2; then compound 1; then compound 3.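

In this assay, going by these compounds alone, the switch at this double bond gives an 11-fold higher number from compound 2 to compound 3 (1.03 log units; beyond the scatter), and this is the first gap that can be tied to a single feature, since compounds 1 and 2 differ in more than one place. The gap can be assigned to the drawn geometry of the double bond alone, because no other part of the structure changes: the fact that compounds 2 and 3 differ only in the configuration as drawn. So this position is not indifferent to configuration, as the E form in compound 2 gives the lower number and the Z form in compound 3 gives the higher one, even though every atom and bond stays the same.

As far as these compounds go, this remains a single pair, so it is open whether the same switch would have an effect of similar size on a relative with a longer chain, or with a carboxylic acid in place of the hydroxamic acid. A cell read-out of this kind also cannot show, on its own, what happens inside the cells to separate the two forms.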